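One Ring Swap, Little Expected Change in Cell Effect

The compounds below may be only part of what the source reports. "The series", "measured", "known", "first", "only" and "open" are said of these compounds alone.

Two compounds share a core and differ only in the ring attached to the carbonyl carbon. Compound 1 `COc1cc(-c2cc(/C=C/C(=O)c3ccc(N)cc3)[nH]n2)cc(OC)c1OC` carries a 4-aminophenyl there, and in a functional assay on MOLT-4 cells (Homo sapiens) for cytotoxicity, read by sulforhodamine B assay, with a stated time of 48 h, tested at 0.01 uM (a lower number here means a stronger effect, a higher number a weaker effect of the compound at the concentration tested), compound 1 gives 101%. Compound 2 `COc1ccc(C(=O)/C=C/c2cc(-c3cc(OC)c(OC)c(OC)c3)n[nH]2)cc1OC` carries a 3,4-dimethoxyphenyl instead, and in this assay compound 2 gives 102%. The step of a number 1 percentage points higher from compound 1 to compound 2 (within the scatter) shows that this exchange made no difference beyond the scatter, so the value of compound 2 sits alongside that of compound 1 rather than apart from it.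

Compound 3 `COc1cc(-c2cc(/C=C/C(=O)c3ccc(F)c(F)c3)[nH]n2)cc(OC)c1OC` is the next variation: 3,4-difluorophenyl in place of 3,4-dimethoxyphenyl on a carbonyl carbon. For the measured compounds named here, the only measured step that bears on this change is the one between the first two compounds, which exchanged one ring on the same carbonyl carbon and produced a number within the scatter. Going by the values given here, nothing among the measured compounds points to a larger effect from a second exchange at that place, so the expected step of a number 2 percentage points lower from compound 2 to compound 3 (within the scatter) is none beyond the scatter. Compound 3 is therefore estimated to give 100% in this assay, with a range from 88% to 110%.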

Compound 3, a percentage reported as activity, at one concentration (the size of the read-out at that concentration, not a potency): 108%
Compound 3: middle estimate off by 8 percentage points, on the low side, and the stated range covers the measured number.
By their numbers in this assay, from the lowest: compounds 1, 2 and 3 (each within the scatter of the next).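

In this assay, 3,4-difluorophenyl in place of 3,4-dimethoxyphenyl on a carbonyl carbon gives a number 6 percentage points higher from compound 2 to compound 3 (within the scatter), and the same ring in place of 4-aminophenyl gives a number 7 percentage points higher from compound 1 to compound 3 (within the scatter) as the second step at this place. The three rings now compared here carry amino, methoxy or fluorine substituents, and the last exchange also goes from a ring of 10 heavy atoms with 2 hydrogen-bond acceptors to one of 8 heavy atoms with 0 hydrogen-bond acceptors, yet none of these differences separates the compounds beyond the scatter at the single concentration tested. No measurement here explains why the numbers stay this close.

Going by these compounds, whether a phenyl ring carrying a carboxylic acid or a trifluoromethyl group on this carbonyl carbon would give a number apart from these three remains open. Also open, on these data alone, is whether compound 1, compound 2 and compound 3 would draw apart at a higher concentration than the one used in this assay and whether changes elsewhere on the shared core would matter more than this one.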